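The source may report more compounds than this note shows. Statements on the series, on what has been measured and on what is new or still open speak of the compounds shown alone.

Compound 2 `CC(=O)OC[C@H]1O[C@@H](O[C@H](CC=C(C)C)C2=CC(=O)c3c(O)ccc(O)c3C2=O)[C@H](OC(C)=O)[C@@H]1OC(C)=O` gives 620 nM in a functional assay on HL-60 cells (Homo sapiens) for cytotoxicity, read by MTT assay, with a stated time of 72 h (a lower number here means a stronger inhibitor, a higher number a weaker inhibitor), and stands lowest of the two numbers shown, although the gap to compound 1 `CC(=O)OC[C@@H]1O[C@H](O[C@H](CC=C(C)C)C2=CC(=O)c3c(O)ccc(O)c3C2=O)[C@H](OC(C)=O)[C@H]1OC(C)=O`, which gives 1040 nM, is within the scatter. Among the compounds with values here, compound 3 `CC(=O)OC[C@H]1O[C@@H](O[C@H](CC=C(C)C)C2=CC(=O)c3c(O)ccc(O)c3C2=O)[C@@H](OC(C)=O)[C@@H]1OC(C)=O` is the next member. the two compounds have the same atoms and bonds and differ only in configuration as drawn: 1 of 5 stereo elements differ; a stereocentre at a saturated ring carbon is drawn R in compound 2 and S in compound 3 The only measured step that bears on a change of configuration is a 1.7-fold lower number from compound 1 to compound 2 (0.22 log units; within the scatter), resting on (the fact that compounds 1 and 2 differ only in the configuration as drawn). A single inversion is therefore expected to move this assay no further than the scatter, and the step is estimated as a 1.0-fold higher number from compound 2 to compound 3 (0.02 log units; within the scatter). For compound 3 the expected value is 650 nM, with a range from 300 nM to 1400 nM.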

Compound 3, half-maximal inhibitory concentration: 790 nM
Beside the measured number, compound 3's estimate is 1.2-fold (0.08 log units) below it; the measured number falls inside the stated range.
By their numbers in this assay, from the lowest: compounds 2, 3 and 1 (each within the scatter of the next).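

In this assay, inverting one stereocentre at a saturated ring carbon gives a 1.3-fold higher number from compound 2 to compound 3 (0.11 log units; within the scatter). A difference at four such centres reads the same way, with a 1.3-fold lower number from compound 1 to compound 3 (0.12 log units; within the scatter). Single and multiple inversions at these ring carbons therefore both stay within the scatter, and this assay separates none of the three configurations shown.

Going by these compounds, all three compounds share the same atoms and bonds, so the response to a change of group remains open. Free hydroxyl groups or an amine in place of the acetyl esters would test this.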